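Swapping the 3,4-dichlorophenyl of compound 1

The source may hold more compounds than are shown below. What is called first, only, known or untested is meant among the compounds shown, and "the series" means these compounds.

In an ADME assay on cells (Astrocyte, Homo sapiens) for cytotoxicity, read by WST assay, with a stated time of 72 h (a higher number here means a weaker inhibitor, a lower number a stronger inhibitor), compound 1 `O=C(Nc1ccc(Cl)c(Cl)c1)Nc1cc2ncncc2cc1OCc1ccccc1F` gives 3900 nM and compound 3 `O=C(Nc1ccc(Cl)c(Cl)c1)Nc1cc2ncncc2cc1OCc1cccc(F)c1` gives 7400 nM, within the scatter of each other. Compound 2 `O=C(Nc1cc2ncncc2cc1OCc1ccc(F)cc1)Nc1cccc2ccccc12` gives 8500 nM, a higher number than compound 1, beyond the scatter. Compound 4 `O=C(Nc1ccccc1F)Nc1cc2ncncc2cc1OCc1ccccc1F` carries 2-fluorophenyl in place of 3,4-dichlorophenyl on an amide-type nitrogen. Among the measured compounds shown here, the only measured step, a 1.9-fold higher number from compound 1 to compound 3 (0.28 log units; within the scatter), concerns a different place, so no measured step covers this change. Compound 2 also lacks 3,4-dichlorophenyl, but it differs from compound 1 in a second place too, so it offers only a weak lean towards a higher number. The expected step stays within the scatter: a 1.5-fold higher number from compound 1 to compound 4 (0.19 log units; within the scatter). For compound 4 the estimate is 6000 nM, with an expected range of 2800 nM to 14000 nM.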

Compound 4, half-maximal inhibitory concentration: 10000 nM
For compound 4 the middle estimate is 1.7-fold (0.22 log units) below the measured one; low and high end bracket the measured number.
By their numbers in this assay, from the lowest: compounds 1, 3, 2 and 4 (each within the scatter of the next, the first and the last beyond it).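

In this assay, the group on the amide-type nitrogen is a place where a single change moves the number beyond the scatter: 2-fluorophenyl in place of 3,4-dichlorophenyl gives a 2.6-fold higher number from compound 1 to compound 4 (0.41 log units; beyond the scatter) as the series' first such step. The earlier step, a 1.9-fold higher number from compound 1 to compound 3 (0.28 log units; within the scatter) within the scatter, concerned a different place. No measured evidence gives a cause for the new step.

From the compounds shown here alone, whether the step follows from removing the two chlorines or from adding the fluorine stays open. An unsubstituted phenyl or a 4-chlorophenyl on this nitrogen would separate the two.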